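Series notes: fluoro to hydrogen on the fused core

The compounds below may be only part of what the source reports. "The series", "measured", "known", "first", "only" and "open" are said of these compounds alone.

Measured compounds:
compound 1 `CN(C)S(=O)(=O)CCNCc1ccc(F)c2cccnc12`, 513000000 nM
compound 2 `CS(=O)(=O)C1(CNCc2ccc(Cl)c3cccnc23)CC1`, 525000000 nM
compound 3 `CS(=O)(=O)C1(CNCc2cccc3cccnc23)CC1`, 479000000 nM

All three were run in an assay on isolated protein for displacement of a labelled ligand from 5-hydroxytryptamine receptor 5A (Homo sapiens), read by radioligand binding, with a stated time of 2 h; on this read-out lower numbers stand for stronger inhibition and higher numbers for weaker inhibition. Compound 1 gives 513000000 nM, the second highest of the three numbers; its nearest neighbour is compound 2, which sits within the scatter of it, and compound 3 is furthest, also within the scatter. None of the three can be ordered against the others.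

Compound 4 `CN(C)S(=O)(=O)CCNCc1cccc2cccnc12` has not yet been measured. It differs from compound 1 by hydrogen in place of fluoro on an aromatic carbon, ortho to a fused ring and para to a large group.

For the measured compounds named here, the only measured step that bears on this change is the removal of a halogen from the same position of the core: a 1.1-fold lower number from compound 2 to compound 3 (0.04 log units; within the scatter). That step stayed within the scatter. Going by the values given here, no step for fluoro itself is available, so the expectation rests on compound 2 and compound 3 alone. For compound 4 the expected step in this assay is therefore a 1.1-fold lower number from compound 1 to compound 4 (0.03 log units; within the scatter), none beyond the scatter.

Compound 4 is estimated at 480000000 nM, in a range from 240000000 nM to 960000000 nM.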

Compound 4, half-maximal inhibitory concentration: 479000000 nM
For compound 4 the middle estimate is 1.0-fold (0.00 log units) above the measured one; measured number inside the range.
By their numbers in this assay, from the lowest: compounds 3, 4, 1 and 2 (each within the scatter of the next).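

In this assay, the step for this exact change is now available: a 1.1-fold lower number from compound 1 to compound 4 (0.03 log units; within the scatter). Until now, the only halogen removal at this position of the shared core involved chloro, on a different side chain, so fluoro had no direct reading. Hydrogen in place of fluoro now joins hydrogen in place of chloro as a step within the scatter, across both side chains, and no information on the reason is available.

The compounds shown carry only hydrogen, fluoro or chloro at this position, so it remains open whether a larger or differently functionalised group, such as methoxy, an amine or a carboxylic acid, would give a step beyond the scatter. On these data alone, whether a longer chain on the side-chain nitrogen would do so also remains open.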